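The source may hold more compounds than are shown below. What is called first, only, known or untested is meant among the compounds shown, and "the series" means these compounds.

Compound 1 `COc1ccc(CNCCCNS(=O)(=O)c2cc(C(F)(F)F)cc(C(F)(F)F)c2)cc1OC` gives 3800 nM in a functional assay on A2780 cells (Homo sapiens) for inhibition, read by MTT assay, with a stated time of 72 h; on this read-out higher numbers stand for weaker inhibition of growth and lower numbers for stronger inhibition of growth.
Compound 2 `O=S(=O)(NCCCNCc1cccc(Cl)c1)c1cc(C(F)(F)F)cc(C(F)(F)F)c1` gives 2200 nM in this assay.
Compound 3 `CN(CCCNS(=O)(=O)c1cc(C(F)(F)F)cc(C(F)(F)F)c1)Cc1ccccc1` gives 28000 nM in this assay.

All three share one core: a sulfonamide carrying two trifluoromethyl groups, joined through a three-carbon chain to an amine nitrogen that bears a benzyl-type group. Among these three numbers, compound 1 stands second highest. Its nearest neighbour is compound 2, reached by a 1.7-fold lower number from compound 1 to compound 2 (0.24 log units; within the scatter). The furthest is compound 3, whose value lies far above that of compound 1, a gap well beyond the scatter.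

Compound 4 `COc1ccccc1CNCCCNS(=O)(=O)c1cc(C(F)(F)F)cc(C(F)(F)F)c1` differs from compound 1 in one place: 2-methoxyphenyl in place of 3,4-dimethoxyphenyl on a saturated chain carbon bound to an amine nitrogen.

The step that bears on this change is a 1.7-fold lower number from compound 1 to compound 2 (0.24 log units; within the scatter), which alters the same aromatic group at the same place and stays within the scatter. The other step, a 13-fold higher number from compound 2 to compound 3 (1.10 log units; beyond the scatter), concerns a different place, the amine nitrogen, and is the only large movement in this set; it does not bear directly on the change to compound 4. Among the compounds with values here, with only one relevant precedent, and that one small, a step within the scatter is expected: a 1.1-fold lower number from compound 1 to compound 4 (0.04 log units; within the scatter).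

Compound 4 is therefore estimated at 3500 nM in this assay, with a range from 1500 nM to 8000 nM.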

Compound 4, concentration for 50% growth inhibition: 1500 nM
The estimate for compound 4 lay 2.3-fold (0.37 log units) above the measured number, and the stated range covers the measured number.
By their numbers in this assay, from the lowest: compounds 4, 2 and 1 (each within the scatter of the next, the first and the last beyond it); then compound 3.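

In this assay, changing the aromatic group at this place now gives a step beyond the scatter, which the earlier change there did not: a 2.5-fold lower number from compound 1 to compound 4 (0.40 log units; beyond the scatter), on going from 3,4-dimethoxybenzyl to 2-methoxybenzyl, with one methoxy group fewer. The group at this place can therefore shift the number modestly, yet the other new comparison gives no order between two quite different groups, since a 1.5-fold lower number from compound 2 to compound 4 (0.17 log units; within the scatter) leaves 2-methoxyphenyl and 3-chlorophenyl level within the scatter. Within the data shown here, the largest new step, a 19-fold lower number from compound 3 to compound 4 (1.27 log units; beyond the scatter), adds a second large gap to compound 3, the only compound here with a methyl group on the amine nitrogen, but this step also changes the aromatic group, so it cannot show what the methyl group alone does.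

Still open, as far as these compounds go, is how this assay would read for a pyridylmethyl group in place of 2-methoxybenzyl, for a longer chain to the sulfonamide nitrogen, or for a methyl group on the amine nitrogen of compound 4. No measurement is available that explains any of these shifts in the number.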